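The source may hold more compounds than are shown below. What is called first, only, known or untested is meant among the compounds shown, and "the series" means these compounds.

Compound 1 `CCCCCCCCCCCCC#Cc1cn([C@H]2CC[C@@H](CO)O2)c(=O)[nH]c1=O`. In an ADME assay on cells (Fibroblast, Homo sapiens) for cytotoxicity, read by MTT assay (on this read-out lower numbers stand for higher toxicity in this test and higher numbers for lower toxicity in this test), compound 1 gives > 100 ug/mL, a limit of the assay.
Compound 2 `CCCCCCCCCCCC#Cc1cn([C@H]2C[C@H](F)[C@@H](CO)O2)c(=O)[nH]c1=O`. In this assay compound 2 gives > 100 ug/mL, a limit of the assay.
Compound 3 `CCCCCCCCC#Cc1cn([C@H]2CC[C@@H](CO)O2)c(=O)[nH]c1=O`. In this assay compound 3 gives > 100 ug/mL, a limit of the assay.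

Compound 3 therefore stands only at a limit, and so do the other two values, all sitting at the limit of > 100 ug/mL in this assay, at which 3 of the 3 values shown sit. Among the compounds with values here, the one step that touches compound 3, a step that the two limits leave unreadable from compound 1 to compound 3, is left unreadable by the two limits.

Compound 4 `CCCCCCCCCCCC#Cc1cn([C@H]2CC[C@@H](CO)O2)c(=O)[nH]c1=O` differs from compound 3 by propyl in place of hydrogen on a saturated chain carbon, eight bonds along the chain from a triple-bonded carbon. Within the data shown here, the only step bearing on this change, a step that the two limits leave unreadable from compound 1 to compound 3, has no readable size, so in this assay no step beyond the scatter is expected in either direction; the expected step that the limit leaves unreadable from compound 3 to compound 4 is none. Compound 4 is expected to give 150 ug/mL (range 70 ug/mL to 500 ug/mL), most probably reported again as a limit.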

Compound 4, half-maximal cytotoxic concentration: > 100 ug/mL
Compound 4: only a limit was reported (the forecaster's own chance of this, stated with the estimate: 85%); the middle value lies beyond the limit too.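

The steps from compound 3, compound 2 and compound 1 to compound 4 cannot be read, as all four compounds stand only at a limit: the limit of > 100 ug/mL in this assay, at which 4 of the 4 values shown sit.

In this assay the compounds shown leave open whether chain length or the fluoro group has any effect.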